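Swapping a Hydroxyethyl Tail for a Morpholine Amide

The source may hold more compounds than are shown below. What is called first, only, known or untested is meant among the compounds shown, and "the series" means these compounds.

compound 1 `CCCCCCCCN(C)C(=O)Cn1cc(Cc2cnc(OCC)nc2)c(=O)nc1SCc1ccc(F)cc1`: 23%
compound 2 `CCCCCCCCN(C)C(=O)Cn1cc(Cc2cnc(=O)n(CCO)c2)c(=O)nc1SCc1ccc(F)cc1`: 59%

In a functional assay on a cell-free system (plasma) for inhibition of platelet-activating factor acetylhydrolase (Homo sapiens), tested at 100 nM (on this read-out higher numbers stand for more inhibition at the one concentration tested (going by the name of the read-out) and lower numbers for less inhibition), compound 2 gives 59%, the higher of the two numbers measured, while compound 1 gives 23%. Among the compounds with values here, the single measured step, a number 36 percentage points higher from compound 1 to compound 2 (beyond the scatter), alters a different part of the shared core and so offers no guide to the change in compound 3 `CCCCCCCCN(C)C(=O)Cn1cc(Cc2cnc(=O)n(CC(=O)N3CCOCC3)c2)c(=O)nc1SCc1ccc(F)cc1`: (morpholin-4-yl)carbonyl in place of hydroxymethyl on a saturated chain carbon bound to an aromatic nitrogen. Lacking any comparable step, compound 3 is expected to show a step of a number 4 percentage points lower from compound 2 to compound 3 (within the scatter), not beyond the scatter. The estimate for compound 3 is 55%, between 35% and 75%.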

Compound 3, a percentage reported as inhibition, at one concentration (the size of the read-out at that concentration, not a potency): 64%
Compound 3: middle estimate off by 9 percentage points, on the low side; measured number inside the range.
By their numbers in this assay, from the lowest: compound 1; then compounds 2 and 3 (each within the scatter of the next).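

In this assay, putting (morpholin-4-yl)carbonyl in place of hydroxymethyl on a saturated chain carbon bound to an aromatic nitrogen gives a number 5 percentage points higher from compound 2 to compound 3 (within the scatter). This position therefore accepts a much larger group carrying a non-aromatic ring and no hydrogen-bond donor, while the two compounds stay within the scatter of each other. Nothing available bears on the reason for this result. The compounds shown leave open how a carboxylic acid or a piperidine amide would read on this same chain carbon.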